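The source may hold more compounds than are shown below. What is called first, only, known or untested is meant among the compounds shown, and "the series" means these compounds.

In an ADME assay on HepG2 2.2.15 cells (Homo sapiens) for cytotoxicity (a higher number here means that more compound is tolerated, a lower number that less compound is tolerated), two compounds sharing one core have been measured so far. Compound 1 `O=C(O)CCCC(=O)OCCc1c(-c2ccccc2Cl)c2cc(Cl)ccc2[nH]c1=O` gives 110000 nM, and compound 2 `O=C(CCC1CCCCC1)OCCc1c(-c2ccccc2Cl)c2cc(Cl)ccc2[nH]c1=O` gives 160000 nM. These two numbers cannot be told apart, with a 1.5-fold higher number from compound 1 to compound 2 (0.16 log units; within the scatter). Compound 2 therefore stands level with compound 1, and neither is set apart as better tolerated.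

Compound 3 `O=C(OCCc1c(-c2ccccc2Cl)c2cc(Cl)ccc2[nH]c1=O)c1ccc([N+](=O)[O-])cc1` keeps the core and alters one group: 4-nitrophenyl in place of 2-cyclohexylethyl on a carbonyl carbon. In short, 4-nitrophenyl comes in place of 2-cyclohexylethyl on a carbonyl carbon. Among the measured compounds shown here, only one measured step bears on this. Cyclohexyl in place of carboxymethyl on a saturated chain carbon, two bonds along the chain from a carbonyl carbon, gave a 1.5-fold higher number from compound 1 to compound 2 (0.16 log units; within the scatter). That step is only a loose guide, as neither measured compound has an aromatic ring at this place. Even so, it offers no reason to expect a step beyond the scatter, in either direction. The expected change is a 1.2-fold lower number from compound 2 to compound 3 (0.09 log units; within the scatter), an estimate rather than a measurement. For compound 3 the estimated value is 130000 nM, with an expected range from 60000 nM to 260000 nM.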

Compound 3, half-maximal cytotoxic concentration: 1600000 nM
Compound 3: the middle estimate sits 12-fold (1.09 log units) below what was measured; the whole stated range lies below it.
By their numbers in this assay, from the lowest: compounds 1 and 2 (each within the scatter of the next); then compound 3.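

In this assay the group on this carbonyl carbon can shift the number well beyond the scatter: 4-nitrophenyl in place of 2-cyclohexylethyl gives a 10-fold higher number from compound 2 to compound 3 (1.00 log units; beyond the scatter) and 4-nitrophenyl in place of 3-carboxypropyl gives a 15-fold higher number from compound 1 to compound 3 (1.16 log units; beyond the scatter), so compound 3 has the highest number of the three and is the best tolerated. Compound 1 and compound 2 both carry a saturated chain here and could not be told apart, so this position looked insensitive until an aromatic ring was placed on the carbonyl carbon. No measurement shown here explains why this change has such a large effect.

The aromatic ring and the nitro group enter together, so the compounds shown cannot say which of them carries the step, or whether both are needed. A plain phenyl group at this place would separate the two, and an amine or a nitrile in place of the nitro group would show whether the effect depends on that particular group.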